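Benzoyl in place of tiglate on a diterpenoid core

The source may report more compounds than this note shows. Statements on the series, on what has been measured and on what is new or still open speak of the compounds shown alone.

Measured compounds:
- compound 1, `C/C=C(/C)C(=O)O[C@@H]1C/C=C(\C)CCCC(C)(C)[C@@H](O)/C=C\1C` — "not active" (no number reported)
- compound 2, `C/C=C(/C)C(=O)O[C@@H]1C/C=C(\C)CCCC(C)(C)[C@@H](OC(C)=O)/C=C\1C` — > 50000 nM
- compound 3, `C/C1=C/[C@H](O)C(C)(C)CCC/C(C)=C/C[C@H]1OC(=O)c1ccccc1` — "not active" (no number reported)

In a functional assay on K562 cells (Homo sapiens) for cytotoxicity, read by MTT assay (a higher number here means a weaker inhibitor, a lower number a stronger inhibitor), compound 1 is reported as "not active" (no number reported), with no number given. Compound 3 likewise is reported in this assay as "not active" (no number reported). Compound 2 gives > 50000 nM in this assay, and this is a limit of the assay, not a measured number; among the three entries it is the only one carrying a figure at all, as the limit of > 50000 nM in this assay, at which 1 of the 3 values shown sits, states. Compound 2 therefore stands at the edge of what this assay can resolve, with nothing else shown to compare it against.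

Compound 4, `CC(=O)O[C@H]1/C=C(/C)[C@H](OC(=O)c2ccccc2)C/C=C(\C)CCCC1(C)C`, has not yet been measured. It differs from compound 2 in one place: phenyl in place of 1-methylprop-1-en-1-yl on a carbonyl carbon. Among the measured compounds shown here, no step between measured compounds is available, so the size of the change cannot be taken from the data. The expectation is for no step beyond the scatter, with compound 4 also likely to return only a limit, the expected step being a step that the limit leaves unreadable from compound 2 to compound 4. Compound 4 is accordingly expected to give about 70000 nM in this assay, within a range from 30000 nM to 200000 nM.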

Compound 4, half-maximal inhibitory concentration: > 50000 nM
Compound 4 gave a limit, no number (the forecaster's own chance of this, stated with the estimate: 85%); the middle value does not contradict the limit.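

Compound 2 and compound 4 both return only a limit in this assay, so no step between them can be read: the limit of > 50000 nM in this assay, at which 2 of the 4 values shown sit.

The compounds shown leave open whether phenyl in place of 1-methylprop-1-en-1-yl on a carbonyl carbon changes the result in this assay at all; none of them carries a measured number.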